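A few compounds are considered here, and "the series" means these few. Any claim that something is new, unique, unknown or untested is made for them only; others in the source may bear on it.

Measured compounds:
- compound 1 `CC1=NN(C(=O)c2ccc([N+](=O)[O-])cc2)C(c2ccccc2O)C1`: 30100 nM
- compound 2 `O=C(CNC1CC1)N1N=C(c2cc3ccccc3oc2=O)CC1c1ccccc1`: "not active" (no number reported)

In a functional assay on HepG2 cells (Homo sapiens) for cytotoxicity, read by MTT assay, with a stated time of 48 h (on this read-out higher numbers stand for weaker inhibition and lower numbers for stronger inhibition), compound 1 gives 30100 nM. In this assay compound 2 is reported only as "not active" (no number reported), so no single number stands for compound 2; it can be placed only as giving no measurable inhibition in this assay, and no comparison of size with compound 1 can be drawn from that.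

Compound 3 `CN1CCN(CC(=O)N2N=C(c3cc4ccccc4oc3=O)CC2c2ccccc2)CC1` is the next member of the series. Its relation to compound 2 is a single change (4-methylpiperazin-1-yl in place of cyclopropylamino on a saturated chain carbon bound to a carbonyl carbon). The rest of the molecule, the shared core of compound 2 with its substituents, is kept.

Among the measured compounds shown here, no step between measured compounds is on record for this series, so there is no measured step of this kind to lean on. With compound 2 giving no measurable inhibition in this assay, the change to compound 3 is expected to leave the read-out at best in the weak range; no step beyond the usual scatter is expected, in either direction. For compound 3 the value in this assay is estimated at 50000 nM, within 15000 nM to 150000 nM, with a sizeable chance that again only inactivity rather than a number is reported.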

Compound 3, half-maximal inhibitory concentration: 33100 nM
The estimate for compound 3 lay 1.5-fold (0.18 log units) above the measured number, and the stated range covers the measured number.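

No step can be read from compound 2 to compound 3: in this assay compound 2 is reported only as "not active" (no number reported), with no number to set against compound 3 at 33100 nM. Nothing measured on the series bears on this result. The compounds shown leave open how far 4-methylpiperazin-1-yl in place of cyclopropylamino shifts the read-out.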